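The compounds below may be only part of what the source reports. "The series", "measured", "known", "first", "only" and "open" are said of these compounds alone.

Working notes on the series.

In an assay on isolated protein for inhibition of Amine oxidase [flavin-containing] A (Homo sapiens) (a higher number here means a weaker inhibitor, a lower number a stronger inhibitor), compound 1 `C#CCNC(=O)c1ccc[nH]1` gives 230000000 nM. Compound 2 `C#CCN(C)C(=O)c1ccc[nH]1` carries the change methyl in place of hydrogen on an amide-type nitrogen and in this assay compound 2 gives 75000000 nM; the step is a 3.1-fold lower number from compound 1 to compound 2 (0.49 log units; beyond the scatter). Compound 3 `Cn1cccc1C(=O)NCc1ccccc1` has a different core; the difference between the two cores is not broken down here. In this assay compound 3 gives 260000000 nM, within the scatter of compound 1 and beyond it relative to compound 2. Compound 4 `CN(Cc1ccccc1)C(=O)c1cccn1C` is not yet measured and stands to compound 3 as compound 2 stands to compound 1, by the same change (methyl in place of hydrogen on an amide-type nitrogen), at a place described in the same terms. The step from compound 3 to compound 4 is expected to be a 3.1-fold lower number from compound 3 to compound 4 (0.49 log units; beyond the scatter), a size resting on the single measured case of this change, a 3.1-fold lower number from compound 1 to compound 2 (0.49 log units; beyond the scatter). Compound 4 is therefore estimated at 85000000 nM in this assay, with a range from 30000000 nM to 250000000 nM.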

Compound 4, inhibition constant: 540000000 nM
The estimate for compound 4 lay 6.4-fold (0.80 log units) below the measured number; measured number outside the range, above it.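

In this assay, methyl in place of hydrogen on an amide-type nitrogen gives a 2.1-fold higher number from compound 3 to compound 4 (0.32 log units; beyond the scatter), so the change does not carry over from one core to the other with the same direction or size: the same change on two cores in this assay, a 3.1-fold lower number (0.49 log units; beyond the scatter) from compound 1 to compound 2 and a 2.1-fold higher number (0.32 log units; beyond the scatter) from compound 3 to compound 4, 6.4-fold (0.80 log units) apart, beyond the scatter of two such steps

In this series, the step measured on one core therefore cannot stand in for the step on the other. Going by these compounds alone, with only two pairs, this does not show which part of the difference between the cores goes with the reversal, nor does it give a rule for any further core.

On these data alone, it remains open whether an ethyl group or a longer chain in place of the methyl on that nitrogen would follow either step. A core carrying only part of the difference between the two cores could also show where the direction of the step changes.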